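Thiophene-linked propanoic acids: ethoxy in place of propynyl

This account rests on a few compounds, and the source may have more. Where it says the series, first, only, none or still open, it means among the compounds named here.

Measured compounds and their values in the calcium flux read-out:
Compound 1 `Cc1cccc(C)c1-c1cccc(COc2ccc(CCC(=O)O)cc2)c1` gives 8 nM.
Compound 2 `Cc1cccc(C)c1-c1cccc(OCc2ccc(CCC(=O)O)s2)c1` gives 2420 nM.
Compound 3 `CC#CC(CC(=O)O)c1ccc(OCc2cccc(-c3c(C)cccc3C)c2)s1` gives 210 nM.

In a functional assay on cells for agonist activity at Free fatty acid receptor 1 (Homo sapiens), read by calcium flux (a higher number here means that more compound is needed for the effect, a lower number that less compound is needed), compound 3 stands second highest of the three numbers; compound 2 sits a step above it, beyond the scatter, and compound 1 a larger step below it, also beyond the scatter. Compound 4 `CCOC(CC(=O)O)c1ccc(OCc2cccc(-c3c(C)cccc3C)c2)s1` is the next member, not yet measured. It differs from compound 3 in one place: ethoxy in place of prop-1-yn-1-yl on a saturated chain carbon bound to an aromatic carbon and a saturated chain carbon. The change keeps the carboxylic acid arm and the shared core of compound 3 and swaps only the substituent on that chain carbon, trading a triple bond for an oxygen that counts as one hydrogen-bond acceptor. Among the measured compounds shown here, no measured pair in this set shows the same change, so the size of the step is not anchored. The expectation for compound 4 is a modest loss, a step of a 1.9-fold higher number from compound 3 to compound 4 (0.28 log units; within the scatter) that may or may not clear the scatter. Compound 4 is estimated at 400 nM, within a range of 120 nM to 1400 nM.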

Compound 4, half-maximal effective concentration: 57 nM
Compound 4: the middle estimate sits 7.0-fold (0.85 log units) above what was measured; the measured number lies below the stated range.
By their numbers in this assay, from the lowest: compound 1; then compound 4; then compound 3; then compound 2.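

In this assay, ethoxy in place of prop-1-yn-1-yl gives a 3.7-fold lower number from compound 3 to compound 4 (0.57 log units; beyond the scatter), so the substituent on the saturated chain carbon bound to an aromatic carbon and a saturated chain carbon does affect the read-out. In this pair the triple bond is not needed for activity, and a group with the same heavy-atom count and one hydrogen-bond acceptor is accepted at this place. Nothing at hand explains the step, and the part played by the entering oxygen cannot be separated from that of the departing triple bond.

As far as these compounds go, whether the step carries over to methoxy, a longer propoxy chain, a hydroxyl or an amine on this carbon stays open. Also open, from the compounds shown here alone, is whether ethoxy on the same chain carbon would behave alike on the core of compound 1.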